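The source may report more compounds than this note shows. Statements on the series, on what has been measured and on what is new or still open speak of the compounds shown alone.

Compound 1 `COCc1cc(CCCOc2c(C)cc(-c3noc(C4CC4)n3)cc2C)on1` is examined in an in vitro ADME assay on microsomes from liver (Simiiformes); on this read-out higher numbers stand for a longer-lived compound and lower numbers for a shorter-lived compound. In this assay compound 1 gives > 2.5 h, which is a limit of the assay rather than a number. Compound 2 `CCc1cc(CCCOc2c(C)cc(-c3noc(C(F)(F)F)n3)cc2C)on1` also gives > 2.5 h, again a limit. Compound 3 `COCc1cc(CCCOc2c(C)cc(-c3noc(C)n3)cc2C)on1` gives 0.5 h, a measured number. Compound 1 and compound 2 share (the limit of > 2.5 h in this assay, at which 2 of the 3 values shown sit). Among the compounds with values here, the only step between measured compounds that differ in a single place is an at least 5.0-fold lower number from compound 1 to compound 3 (0.69 log units; beyond the scatter), and it concerns a group at a different place in the molecule from the one changed here.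

Compound 4 `Cc1cc(CCCOc2c(C)cc(-c3noc(C4CC4)n3)cc2C)on1` differs from compound 1 by hydrogen in place of methoxy on a saturated chain carbon bound to an aromatic carbon. Within the data shown here, no measured step touches this group, so the data give no direct guide to how the half-life will respond. Among the measured compounds shown here, the only step available involves a different group, and its size cannot be carried over. Compound 4 is therefore expected to give an estimated 2.5 h, between 1.2 h and 2.5 h, and the assay may again report only a limit. That amounts to an expected step of a number no higher from compound 1 to compound 4 (the limit leaves the size open).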

Compound 4, half-life: 2.23 h
Compound 4: middle estimate off by 1.1-fold (0.05 log units), on the high side; measured number inside the range.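

Methoxymethyl to methyl is the first change at this place to have a measured outcome, and the step is an at least 1.1-fold lower number from compound 1 to compound 4 (0.04 log units; that floor lies within the scatter). In this assay compound 4 gives 2.23 h, a measured number, so the methoxy is not required for a half-life of this length in a compound built on this core. The true size of the step stays unknown, and a larger drop cannot be excluded, because compound 1 stands at a limit and not at a number: the limit of > 2.5 h in this assay, at which 2 of the 4 values shown sit.

The compounds shown leave open how an amine, a carboxylic acid or a longer chain at this place would affect the half-life. On these data alone, it is also open whether the same change would act alike with methyl in place of cyclopropyl, as in compound 3, which gives 0.5 h.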